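A bicyclic sulfonyl group in place of bromophenyl

The source may report more compounds than this note shows. Statements on the series, on what has been measured and on what is new or still open speak of the compounds shown alone.

Compound 3 `O=S(=O)(c1cccc(Br)c1)c1cn(C2CCCNC2)c2ncccc12` gives 3.8 nM in an assay on HeLa cells for displacement of a labelled ligand from 5-hydroxytryptamine receptor 6 (Homo sapiens) (a lower number here means a stronger inhibitor, a higher number a weaker inhibitor), the highest of the three numbers shown. For the measured compounds named here, compound 2 `O=S(=O)(c1ccccc1Cl)c1cn(C2CCCNC2)c2ncccc12` gives 3.7 nM in this assay, and the one single-point step, a 1.0-fold higher number from compound 2 to compound 3 (0.01 log units; within the scatter), lies within the scatter. Going by the values given here, compound 1 `O=S(=O)(C1=C(Cl)NC2SC=CN12)c1cn(C2CCNC2)c2ncccc12` gives 1 nM in this assay; it differs from compound 3 in two places, so no single step is given, yet its number stands beyond the scatter from that of compound 3. Compound 4 `O=S(=O)(C1=C(Cl)NC2SC=CN12)c1cn(C2CCCNC2)c2ncccc12` carries a group of 9 heavy atoms (5 carbon, 2 nitrogen, 1 sulfur, 1 chlorine; 2 five-membered non-aromatic rings with 2 hetero atoms each) in place of a group of 7 heavy atoms (6 carbon, 1 bromine; one six-membered aromatic ring of carbon only), on a sulfonyl sulfur. Compound 4 shares this sulfonyl group with compound 1 and the saturated ring with compound 3, so the number is expected to move toward that of compound 1, which gives 1 nM. Compound 4 is therefore expected to show a 2.5-fold lower number from compound 3 to compound 4 (0.40 log units; beyond the scatter). Compound 4 is estimated at 1.5 nM, within 0.5 nM to 4.5 nM.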

Compound 4, inhibition constant: 0.7 nM
Beside the measured number, compound 4's estimate is 2.1-fold (0.33 log units) above it; low and high end bracket the measured number.
By their numbers in this assay, from the lowest: compounds 4 and 1 (each within the scatter of the next); then compounds 2 and 3 (each within the scatter of the next).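

In this assay the bicyclic sulfonyl group can now be set directly against both aryl groups on the same piperidin-3-yl compound (a 5.4-fold lower number from compound 3 to compound 4 (0.73 log units; beyond the scatter); a 5.3-fold lower number from compound 2 to compound 4 (0.72 log units; beyond the scatter)), so the change on the sulfonyl sulfur alone moves the number. With this group in place, piperidin-3-yl in place of pyrrolidin-3-yl on an aromatic nitrogen leaves the two compounds level (a 1.4-fold lower number from compound 1 to compound 4 (0.15 log units; within the scatter)). No evidence on the reason for the shift is at hand. The compounds shown leave open whether the chlorine of the bicyclic group is needed, since no compound carries hydrogen or methyl there.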